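Swapping a Two-Ring Amide Cap for an Iodophenyl

The source may report more compounds than this note shows. Statements on the series, on what has been measured and on what is new or still open speak of the compounds shown alone.

Measured compounds:
- Compound 2 `COC(=O)c1scc(-c2ccc(NC(=O)c3ccc4ccccc4c3)cc2)c1OC` gives 18200 nM in a functional assay on HeLa cells (Homo sapiens) for antiproliferative activity, read by MTT assay, with a stated time of 24 h; a higher number here means a weaker inhibitor, a lower number a stronger inhibitor.
- Compound 3 `COC(=O)c1scc(-c2ccc(NC(=O)c3ccc(F)c(Cl)n3)cc2)c1OC` gives 16200 nM in this assay.
- For compound 1 `COC(=O)c1scc(-c2ccc(NC(=O)c3cc(I)ccc3F)cc2)c1OC` the entry in this assay reads "not determined" (no result reported), so no number is available for it.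

For the measured compounds named here, compound 2 has the highest of the two numbers that were obtained, but its only neighbour, compound 3, sits within the scatter of it: a 1.1-fold lower number from compound 2 to compound 3 (0.05 log units; within the scatter). On this small set, then, replacing the naphthalen-2-yl group on the carbonyl carbon with a quite different ring has left the number essentially unchanged.

Compound 4 `COC(=O)c1scc(-c2ccc(NC(=O)c3cccc(I)c3)cc2)c1OC` is the next variation of the same shared core. Its change from compound 2 is this: 3-iodophenyl in place of naphthalen-2-yl on a carbonyl carbon

Going by the values given here, only the step from compound 2 to compound 3 bears on this change, and it stayed within the scatter. It concerns a different incoming group, so it is a loose guide, yet nothing here points to a sizeable shift in either direction. Compound 4 is therefore expected to land close to compound 2 in this assay, with the step of a 1.1-fold higher number from compound 2 to compound 4 (0.04 log units; within the scatter) expected to stay within the scatter. The estimate for compound 4 is 20000 nM, with a range from 8000 nM to 50000 nM.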

Compound 4, half-maximal inhibitory concentration: 12700 nM
The estimate for compound 4 lay 1.6-fold (0.20 log units) above the measured number, within the range that was stated.
By their numbers in this assay, from the lowest: compounds 4, 3 and 2 (each within the scatter of the next).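

In this assay, the group on the carbonyl carbon can change from the two-ring naphthalen-2-yl to the one-ring 3-iodophenyl, and this gives a 1.4-fold lower number from compound 2 to compound 4 (0.16 log units; within the scatter), so the second ring is not needed to keep the number in this range. The step to 3-iodophenyl in place of 6-chloro-5-fluoropyridin-2-yl gives a 1.3-fold lower number from compound 3 to compound 4 (0.11 log units; within the scatter), which means all three groups tested at this position give numbers that cannot be told apart. Nothing available explains why these different groups read alike.

As far as these compounds go, all three groups are aromatic rings, so it remains open whether an amine, a carboxylic acid or a longer chain on the carbonyl carbon would move the number beyond the scatter. Compound 1, with its fluorine and iodine ring, has no number to compare.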